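The source may hold more compounds than are shown below. What is called first, only, known or untested is meant among the compounds shown, and "the series" means these compounds.

Compound 1 `CC(C)=CCC/C(C)=C/CC/C(C)=C/CC[C@]1(C)CCc2cc(OC(=O)NC(=O)Oc3ccccc3)cc(C)c2O1` is built from a long unsaturated chain joined to a bicyclic core that bears a (phenoxycarbonyl)carbamoyl group on one of its ring positions. In a functional assay on MDA-MB-231 cells (Homo sapiens) for antiproliferative activity, read by MTT assay, with a stated time of 96 h (a higher number here means a weaker inhibitor, a lower number a stronger inhibitor), compound 1 has no number at all: the entry for compound 1 reads "not determined" (no result reported), so there is nothing to place it against. Among the measured compounds shown here, the only measured relative is compound 2 `CC(C)=CCC/C(C)=C/CC/C(C)=C/CC[C@]1(C)CCc2c(C)c(OC(=O)NCc3ccccc3)c(C)c(C)c2O1`, which carries a different carbamate on a more heavily methylated core; in this assay compound 2 gives 7200 nM. Compound 3 `CC(C)=CCC/C(C)=C/CC/C(C)=C/CC[C@]1(C)CCc2cc(OC(=O)Nc3ccccc3)cc(C)c2O1` is compound 1 after a single change: phenyl in place of phenoxycarbonyl on an amide-type nitrogen. For the measured compounds named here, since no step between two measured compounds is known here, the size and direction of this change cannot be read from the data, and the outcome for compound 3 may fall anywhere around the one value seen. Compound 3 is therefore estimated at 6000 nM, with a range from 1500 nM to 25000 nM, and this is only an expectation.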

Compound 3, half-maximal inhibitory concentration: > 10000 nM
Compound 3: no number, only a limit; the forecaster's own chance of this, stated with the estimate: 15%; at least 1.6-fold (0.22 log units) between middle value and limit.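

Compound 3 gives > 10000 nM in this assay, which is a limit and not a number. Among the compounds shown here, no step from compound 1 to compound 3 can be read. The compounds shown leave open how much phenyl in place of phenoxycarbonyl on the amide-type nitrogen changes activity.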